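A few compounds are considered here, and "the series" means these few. Any claim that something is new, unique, unknown or untested is made for them only; others in the source may bear on it.

Three compounds have been measured in an ADME assay on HeLa cells (Homo sapiens) for cytotoxicity, read by resazurin assay, with a stated time of 2 days; a higher number here means a weaker inhibitor, a lower number a stronger inhibitor:

Compound 1 `Cn1c([N+](=O)[O-])cnc1/C=C/c1ccccc1Br`: 72400 nM
Compound 2 `Cn1c([N+](=O)[O-])cnc1/C=C/c1cccc(Br)c1`: 87100 nM
Compound 3 `Cn1c([N+](=O)[O-])cnc1CCc1ccccc1`: > 100000 nM

Compound 1 and compound 2 each gave a number, and those two numbers lie within the usual scatter of each other. Compound 3 gave > 100000 nM, which is a limit of the assay and not a number. Among the measured compounds shown here, it is the only compound standing there: the limit of > 100000 nM in this assay, at which 1 of the 3 values shown sits.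

Compound 4 `Cc1ccc(CCc2ncc([N+](=O)[O-])n2C)cc1` follows from compound 3 by one small change, methyl in place of hydrogen on an aromatic carbon, para to a large group: methyl in place of hydrogen on an aromatic carbon. For the measured compounds named here, no step between measured compounds is available to size this change. In this assay, therefore, no shift beyond the scatter is expected, in either direction, and the expectation rests on compound 3 at > 100000 nM alone. The estimated change is a number no higher from compound 3 to compound 4 (the limit leaves the size open). For compound 4 the expected value is 100000 nM, with an estimated range from 55000 nM to 180000 nM.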

Compound 4, half-maximal inhibitory concentration: > 100000 nM
Compound 4: only a limit was reported; the forecaster's own chance of this, stated with the estimate: 65%; the middle value lies on the limit itself.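

Compound 3 and compound 4 each give only a limit and not a number in this assay, and no step between them can be read: the limit of > 100000 nM in this assay, at which 2 of the 4 values shown sit.

The compounds shown leave open whether methyl in place of hydrogen on an aromatic carbon, para to a large group, changes the reading in this assay at all.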